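Benzyl ring substituent series: expectation for compound 4

This account rests on a few compounds, and the source may have more. Where it says the series, first, only, none or still open, it means among the compounds named here.

Compound 3 `Cc1ccccc1CNc1nc2c(N)ncnc2n1[C@@H]1O[C@H](CO)[C@@H](O)[C@H]1O` carries 2-methylphenyl on a saturated chain carbon bound to a nitrogen on an aromatic ring. Among the measured compounds shown here, in an assay on COS-7 cells for inhibition of sodium/nucleoside cotransporter 2 (Homo sapiens), read by scintillation counting, in the presence of a further agent that is not named here (a higher number here means a weaker inhibitor, a lower number a stronger inhibitor), compound 3 gives 65000 nM, the highest of the two numbers measured so far in this assay. Compound 2 `Cc1cccc(CNc2nc3c(N)ncnc3n2[C@@H]2O[C@H](CO)[C@@H](O)[C@H]2O)c1` gives 19000 nM in this assay. Compound 1 `COc1ccccc1CNc1nc2c(N)ncnc2n1[C@@H]1O[C@H](CO)[C@@H](O)[C@H]1O` reaches only the limit > 100000 nM in this assay, a limit rather than a number (the limit of > 100000 nM in this assay, at which 1 of the 3 values shown sits). The measured steps run an at least 5.2-fold lower number from compound 1 to compound 2 (0.72 log units; beyond the scatter), an at least 1.5-fold lower number from compound 1 to compound 3 (0.18 log units; that floor lies within the scatter) and a 3.4-fold higher number from compound 2 to compound 3 (0.53 log units; beyond the scatter).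

Compound 4 `Nc1ncnc2c1nc(NCc1cccc(Cl)c1)n2[C@@H]1O[C@H](CO)[C@@H](O)[C@H]1O` differs from compound 3 by 3-chlorophenyl in place of 2-methylphenyl on a saturated chain carbon bound to a nitrogen on an aromatic ring. For the measured compounds named here, no measured step swaps methyl for chlorine on this ring; the nearest guide is compound 2, whose 3-methylphenyl sits on the same chain carbon as the 3-chlorophenyl of compound 4, and compound 2 stands at 19000 nM. The step of a 3.4-fold higher number from compound 2 to compound 3 (0.53 log units; beyond the scatter) therefore suggests that compound 4, with its 3-chlorophenyl, is expected to come out below compound 3 by roughly that margin, reversed: an estimated step of a 2.6-fold lower number from compound 3 to compound 4 (0.41 log units; beyond the scatter). Compound 4 is expected at 25000 nM, within 8000 nM to 80000 nM in this assay.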

Compound 4, half-maximal inhibitory concentration: 5400 nM
For compound 4 the middle estimate is 4.6-fold (0.67 log units) above the measured one; measured number below the stated range.
By their numbers in this assay, from the lowest: compound 4; then compound 2; then compound 3. At a limit, above all of these: compound 1.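

In this assay, the change from 3-methylphenyl to 3-chlorophenyl alters the ring substituent while leaving the rest of the molecule unchanged, and it still moves the result beyond the scatter: a 3.5-fold lower number from compound 2 to compound 4 (0.55 log units; beyond the scatter). The change from 2-methylphenyl to 3-chlorophenyl is larger, and this position on a saturated chain carbon bound to a nitrogen on an aromatic ring can carry a much lower number than compound 3 showed: a 12-fold lower number from compound 3 to compound 4 (1.08 log units; beyond the scatter). The comparison with 2-methoxyphenyl gives only a floor, an at least 18-fold lower number from compound 1 to compound 4 (1.26 log units; beyond the scatter), and compound 1 stands at a limit: the limit of > 100000 nM in this assay, at which 1 of the 4 values shown sits.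

Chlorine appears here only as 3-chlorophenyl, so the compounds shown cannot separate the effect of the atom from that of its place on the ring. From the compounds shown here alone, whether bromine, an amine or a carboxylic acid on this ring would keep or lose the lower number remains open.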